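This account rests on a few compounds, and the source may have more. Where it says the series, first, only, none or still open, it means among the compounds named here.

Compounds measured in an assay on tissue (RPTEC cells) for inhibition of solute carrier family 22 member 12 (Homo sapiens), read by scintillation counting, with stated times of 15 min and 2 h; on this read-out higher numbers stand for weaker inhibition and lower numbers for stronger inhibition:
compound 1 `N#Cc1cc(C(=O)N2CS(=O)(=O)c3ccccc32)cc(C(F)(F)F)c1O` — > 100000 nM
compound 2 `CCc1cc(C(=O)N2CS(=O)(=O)c3ccccc32)cc(C#N)c1O` — > 100000 nM

Both values are limits of this assay, not numbers (the limit of > 100000 nM in this assay, at which 2 of the 2 values shown sit). Compound 2 stands at a limit in this assay, so its true value is not known. The step from compound 1 to compound 2 is a step that the two limits leave unreadable from compound 1 to compound 2; ethyl in place of trifluoromethyl on an aromatic carbon.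

Compound 3 `C#Cc1cc(C(=O)N2CS(=O)(=O)c3ccccc32)cc(C#N)c1O` differs from compound 2 by ethynyl in place of ethyl on an aromatic carbon. For the measured compounds named here, no measured step reads on this change, since both values shown are limits. Compound 3 is therefore expected to sit at a limit as well, estimated at 150000 nM within 50000 nM to 500000 nM. The expected step from compound 2 to compound 3 in this assay is a step that the limit leaves unreadable from compound 2 to compound 3.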

Compound 3, half-maximal inhibitory concentration: 3200 nM
For compound 3 the middle estimate is 47-fold (1.67 log units) above the measured one, and the stated range ends above it.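

In this assay, the position ortho to a hydroxy group proves sensitive to the group it carries: ethynyl in place of ethyl gives an at least 31-fold lower number from compound 2 to compound 3 (1.49 log units; beyond the scatter). Ethynyl in place of trifluoromethyl gives an at least 31-fold lower number from compound 1 to compound 3 (1.49 log units; beyond the scatter). The step between the other two compounds cannot be read, so ethyl and trifluoromethyl remain unranked: the limit of > 100000 nM in this assay, at which 2 of the 3 values shown sit.

Open, on these data alone, is whether a longer chain, such as propynyl, or a small amine at this position would keep the readable value of compound 3. Also open, as far as these compounds go, is whether the gain from ethynyl depends on the cyano group elsewhere on the ring.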